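This account rests on a few compounds, and the source may have more. Where it says the series, first, only, none or still open, it means among the compounds named here.

Compound 1 `OC[C@H]1O[C@@H](n2cnc3c(CSCc4ccccc4)ncnc32)[C@H](O)[C@@H]1O` in a functional assay on Huh-7 cells (Homo sapiens) for cytotoxicity, read by MTT assay, with a stated time of 3 days (a higher number here means that more compound is tolerated, a lower number that less compound is tolerated), gives > 100000 nM, which is a limit of the assay and not a number. Compound 1 therefore stands only at the limit of > 100000 nM in this assay, at which 1 of the 2 values shown sits, in this assay, with no number of its own. Compound 2 `OC[C@H]1O[C@@H](n2cnc3c(CS)ncnc32)C[C@@H]1O` in this assay gives 41000 nM. Compound 3 `CC(C)N(Cc1ncnc2c1ncn2[C@@H]1O[C@H](CO)[C@@H](O)[C@H]1O)C(C)C` carries diisopropylamino in place of benzylsulfanyl on a saturated chain carbon bound to an aromatic carbon. No step between measured compounds is shown. Because compound 1 sits at the limit of > 100000 nM in this assay, at which 1 of the 2 values shown sits, the step of a number no higher from compound 1 to compound 3 (the limit leaves the size open) is expected to be none beyond the scatter in this assay. Compound 3 in this assay is estimated at 100000 nM, with a range of 30000 nM to 300000 nM.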

Compound 3, half-maximal cytotoxic concentration: 18000 nM
Compound 3: middle estimate off by 5.6-fold (0.74 log units), on the high side; measured number below the stated range.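

In this assay, diisopropylamino in place of benzylsulfanyl on a saturated chain carbon bound to an aromatic carbon gives an at least 5.5-fold lower number from compound 1 to compound 3 (0.74 log units; beyond the scatter). The group at this place therefore bears on how much compound is tolerated, and the ringless amine is the less tolerated of the two. The full size of the step stays open because compound 1 carries a limit and not a number: the limit of > 100000 nM in this assay, at which 1 of the 3 values shown sits.

The change swaps sulfur for nitrogen and also removes the aromatic ring, and the two are not separated here. Benzylamino or isopropylsulfanyl at this place would separate them.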